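A few compounds are considered here, and "the series" means these few. Any claim that something is new, unique, unknown or untested is made for them only; others in the source may bear on it.

Compound 1, `CC(C)[C@H](NC(=O)COc1cccc2ccccc12)C(=O)N[C@@H](CC(=O)O)C(=O)CSc1nc(-c2ccccc2)cs1`: in a functional assay on Jurkat cells (Homo sapiens) for inhibition (a higher number here means a weaker inhibitor, a lower number a stronger inhibitor), compound 1 gives > 200000 nM, which is a limit of the assay and not a number.
Compound 2, `CC(C)[C@H](NC(=O)COc1cccc2ccccc12)C(=O)N[C@@H](CC(=O)O)C(=O)CSc1nccc(C(F)(F)F)n1`: in this assay compound 2 gives > 200000 nM, again a limit.
Compound 3, `CC(C)[C@H](NC(=O)COc1cccc2ccccc12)C(=O)N[C@@H](CC(=O)O)C(=O)COc1ncnc2ccccc12`: in this assay compound 3 gives > 200000 nM, again a limit.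

Compound 3 therefore stands where every measured compound stands: at the limit of > 200000 nM in this assay, at which 3 of the 3 values shown sit. For the measured compounds named here, no compound in this set has a numerical reading, and so none can be called stronger or weaker than another. The three steps that connect them, a step that the two limits leave unreadable from compound 1 to compound 2, a step that the two limits leave unreadable from compound 1 to compound 3 and a step that the two limits leave unreadable from compound 2 to compound 3, all sit between two limits and their size cannot be read.

The change to compound 4, `CC(C)[C@H](NC(=O)COc1cccc2ccccc12)C(=O)N[C@@H](CC(=O)O)C(=O)COc1cncc2ccccc12`, is isoquinolin-4-yl in place of quinazolin-4-yl on an oxygen on a saturated carbon. It touches the same part of the molecule as the steps from compound 1 and compound 2 to compound 3, but those steps give no readable size and so offer no direction for the new step. With three limits and nothing else, the expectation for the step that the limit leaves unreadable from compound 3 to compound 4 rests only on compound 3 staying where the set stands, and compound 4 is expected most likely to be reported again as a limit. Compound 4 is estimated at 300000 nM, within a range of 80000 nM to 1000000 nM.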

Compound 4, half-maximal inhibitory concentration: 166000 nM
Estimate against measurement, compound 4: 1.8-fold (0.26 log units) above, within the range that was stated.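

With compound 4 the set gains its first numerical reading, so isoquinolin-4-yl in place of quinazolin-4-yl on an oxygen on a saturated carbon can be given a floor, printed as an at least 1.2-fold lower number from compound 3 to compound 4 (0.08 log units; that floor lies within the scatter) in this assay. The same holds for the exchanges of the two sulfanyl groups for (isoquinolin-4-yl)oxy on a saturated chain carbon bound to a carbonyl carbon, which read as an at least 1.2-fold lower number from compound 2 to compound 4 (0.08 log units; that floor lies within the scatter) and as an at least 1.2-fold lower number from compound 1 to compound 4 (0.08 log units; that floor lies within the scatter), while the steps among compounds 1, 2 and 3 still cannot be read. Each floor lies within the scatter, so this position now yields a number but no demonstrated gain, and the rest of the set remains at a limit: the limit of > 200000 nM in this assay, at which 3 of the 4 values shown sit.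

From the compounds shown here alone, how far compound 4 truly lies from compound 3 stays open, as the reading of compound 3 is a limit and only a floor can be given for the step. The compounds shown also leave open how the isoquinolin-4-yl group would read with an amine or a methoxy group on it, or when joined through sulfur in place of the oxygen.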